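A few compounds are considered here, and "the series" means these few. Any claim that something is new, unique, unknown or untested is made for them only; others in the source may bear on it.

In an ADME assay on HEK293 cells (Homo sapiens) for cytotoxicity, read by MTT assay, with a stated time of 48 h (on this read-out lower numbers stand for stronger inhibition and higher numbers for weaker inhibition), compound 1 (`O=C1CS/C(=N/c2ccccc2)N1Cc1ccncc1`) gives 99500 nM and compound 2 (`Cc1ccc(/C=C2/S/C(=N/c3ccccc3)N(Cc3ccncc3)C2=O)cc1`) gives 49500 nM on the same read-out. These two numbers lie within the scatter of each other, so compound 2 does not stand apart from compound 1 in this small set. Compound 3 (`COc1ccc(/C=C2/S/C(=N/c3ccccc3)N(Cc3ccncc3)C2=O)cc1`) is still unmeasured. It differs from compound 2 in one place: methoxy in place of methyl on an aromatic carbon, para to a large group, so that 4-methylphenyl becomes 4-methoxyphenyl (methoxy in place of methyl on an aromatic carbon). Among the measured compounds shown here, no measured pair shows this change, so there is no direct precedent for it. For the measured compounds named here, the only guide is the close agreement of the two numbers at hand, with compound 1 at 99500 nM and compound 2 at 49500 nM on this read-out. Accordingly, no shift beyond the scatter is expected in this assay and neither direction is favoured. The expected step is a 1.0-fold higher number from compound 2 to compound 3 (0.00 log units; within the scatter) and it is estimated to stay inside the scatter. The estimate for compound 3 is 50000 nM with an expected range of 22000 nM to 110000 nM for the coming measurement.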

Compound 3, half-maximal inhibitory concentration: 47900 nM
Compound 3: the middle estimate sits 1.0-fold (0.02 log units) above what was measured; low and high end bracket the measured number.
By their numbers in this assay, from the lowest: compounds 3, 2 and 1 (each within the scatter of the next, the first and the last beyond it).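

In this assay, among the compounds shown here, the only measured pair for this change gives a 1.0-fold lower number from compound 2 to compound 3 (0.01 log units; within the scatter), so methoxy in place of methyl on an aromatic carbon, para to a large group, now has a direct precedent, and it lies within the scatter. Going from 4-methylphenyl to 4-methoxyphenyl adds one oxygen and one hydrogen-bond acceptor, and in this single pair that difference does not separate the two numbers. No supporting measurement bears on the reason for this result.

From the compounds shown here alone, because the comparison covers only methyl and methoxy, it remains open whether an amine, a carboxylic acid, a halogen such as fluorine or a longer chain such as butoxy at the same place would give a step beyond the scatter. Going by these compounds, it also remains open whether the methyl-to-methoxy step would stay this small on a compound with a different group in place of the phenyl or pyridinylmethyl parts of the shared core.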